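A few compounds are considered here, and "the series" means these few. Any claim that something is new, unique, unknown or untested is made for them only; others in the source may bear on it.

Measured so far in an ADME assay on MT4 cells (Homo sapiens) for cytotoxicity, read by MTT assay, with a stated time of 4 days; a higher number here means that more compound is tolerated, a lower number that less compound is tolerated:
compound 1 `CNC(=O)Nc1c(C)c(C(OC(C)(C)C)C(=O)O)c(-c2ccc(C)c(C)c2)c(C)c1-c1ccc(C)c(C)c1` gives 20000 nM
compound 2 `Cc1ccc(-c2c(C)c(-c3ccc(C)c(C)c3)c(C(OC(C)(C)C)C(=O)O)c(C)c2NS(=O)(=O)C2CC2)cc1C` gives 11000 nM

Compound 2 stands within the scatter of compound 1 in this assay: a 1.8-fold lower number from compound 1 to compound 2 (0.26 log units; within the scatter). Compound 3 `Cc1ccc(-c2c(C)c(-c3ccc(C)c(C)c3)c(C(OC(C)(C)C)C(=O)O)c(C)c2NCc2ccccc2)cc1C` differs from compound 2 by benzyl in place of cyclopropylsulfonyl on a nitrogen on an aromatic ring. Among the compounds with values here, the only step that bears on this change is the exchange at the same nitrogen between compound 1 and compound 2, a 1.8-fold lower number from compound 1 to compound 2 (0.26 log units; within the scatter), which stayed within the scatter. No step beyond the scatter is therefore expected in this assay from compound 2 to compound 3, a 1.1-fold higher number from compound 2 to compound 3 (0.04 log units; within the scatter). Compound 3 is estimated at 12000 nM, with a range from 5000 nM to 30000 nM.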

Compound 3, half-maximal cytotoxic concentration: 4000 nM
The estimate for compound 3 lay 3.0-fold (0.48 log units) above the measured number; measured number below the stated range.
By their numbers in this assay, from the lowest: compound 3; then compounds 2 and 1 (each within the scatter of the next).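

In this assay the group on a nitrogen on an aromatic ring now proves able to shift the number beyond the scatter, with benzyl giving a 2.8-fold lower number from compound 2 to compound 3 (0.44 log units; beyond the scatter) and also a 5.0-fold lower number from compound 1 to compound 3 (0.70 log units; beyond the scatter). Methylcarbamoyl and cyclopropylsulfonyl remain within the scatter of each other, so among these three compounds only benzyl stands apart, and the position is not indifferent to its substituent. No measurement at hand bears on the reason for this shift.

Open, going by these compounds, is whether the aromatic ring of benzyl carries the step, which a cyclohexylmethyl group on the same nitrogen would test. Also open, on these data alone, is how a longer alkyl chain there would read.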